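The source may report more compounds than this note shows. Statements on the series, on what has been measured and on what is new or still open speak of the compounds shown alone.

Measured in a functional assay on SW-620 cells (Homo sapiens) for cytotoxicity; a higher number here means a weaker inhibitor of growth, a lower number a stronger inhibitor of growth:
- Compound 1 `COc1ccc(C2=C(c3cc(OC)c(OC)c(OC)c3)CC3CCCN3C2=O)cc1O`: > 100000 nM
- Compound 2 `CSc1ccc(C2=C(c3ccc(F)c(F)c3)C(=O)N3CCCC3C2)cc1`: 200 nM

Compound 1 gives > 100000 nM, which is a limit of the assay and not a number.

Among the compounds with values here, compound 2 gives 200 nM, the only true number available, so there is no series against which to rank it. Its value is the sole starting point for what follows.

Compound 3 `CSc1ccc(C2=C(c3ccc(O)cc3)C(=O)N3CCCC3C2)cc1` keeps the shared core and the 4-(methylsulfanyl)phenyl group of compound 2 and changes in one place: 4-hydroxyphenyl in place of 3,4-difluorophenyl on a double-bonded ring carbon.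

Within the data shown here, no measured pair shows what this exchange does in this assay, so the expectation rests on compound 2 at 200 nM alone and must stay broad. A moderate loss of growth inhibition seems the more likely direction, somewhat beyond the usual scatter, although a result within the scatter would not be surprising.

The estimated change runs a 4.0-fold higher number from compound 2 to compound 3 (0.60 log units; beyond the scatter).

For compound 3 the expected value is 800 nM, with an estimated range of 120 nM to 6000 nM.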

Compound 3, concentration for 50% growth inhibition: > 100000 nM
Compound 3: no number, only a limit; the forecaster's own chance of this, stated with the estimate: 8%; middle value at least 120-fold (2.09 log units) away from the limit.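

In this assay, within the data shown here, placing 4-hydroxyphenyl instead of 3,4-difluorophenyl on the double-bonded ring carbon gives an at least 500-fold higher number from compound 2 to compound 3 (2.69 log units; beyond the scatter), the first measured pair in this set and evidence that growth inhibition depends strongly on the group at this position. Compound 3 gives > 100000 nM, which is a limit of the assay and not a number. The step therefore marks only the smallest change consistent with the data, and its full size cannot be read because the measurement of compound 3 ends at a limit: the limit of > 100000 nM in this assay, at which 2 of the 3 values shown sit.

This single exchange removes both fluorine atoms and adds a hydroxyl group at once, so the compounds shown cannot tell whether the loss of the fluorines, the arrival of the hydroxyl or both account for the drop. A 4-fluorophenyl group, which keeps one fluorine without a hydroxyl, or a 4-methoxyphenyl group, which places an oxygen there without the hydroxyl hydrogen, would help separate these possibilities at the same position.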